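Swapping Diethylamino for Cyclopropylamino on a Dithiocarbamate

A few compounds are considered here, and "the series" means these few. Any claim that something is new, unique, unknown or untested is made for them only; others in the source may bear on it.

Three measured compounds share one core and differ only in the group attached to the thiocarbonyl carbon. Compound 1 `CCN(CC)C(=S)SCC1=CCOC1=O` carries a diethylamino group there. In a functional assay on MCF7 cells (Homo sapiens) for antiproliferative activity, read by MTT assay, with a stated time of 72 h (a lower number here means a stronger inhibitor, a higher number a weaker inhibitor), compound 1 gives 121000 nM. Compound 2 `CN1CCN(C(=S)SCC2=CCOC2=O)CC1` gives 86500 nM in this assay, and compound 3 `Cc1ccc(NC(=S)SCC2=CCOC2=O)cc1` gives 97400 nM. Compound 1 has the highest number of the three, but its gaps to compound 3 and to compound 2 both fall inside the usual spread of repeat measurements, so the three cannot be put in any order of strength; all three are weak inhibitors.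

Compound 4 `O=C1OCC=C1CSC(=S)NC1CC1` differs from compound 1 by cyclopropylamino in place of diethylamino on a thiocarbonyl carbon. Going by the values given here, no pair of measured compounds records what a change at this position does on its own. Among the compounds with values here, compound 3, the only other compound with a hydrogen-bearing nitrogen on the thiocarbonyl carbon, gives 97400 nM, which sits close to compound 1. On that basis the expected step in this assay is a 1.2-fold lower number from compound 1 to compound 4 (0.08 log units; within the scatter), that is, nothing beyond the usual spread in either direction. Compound 4 is therefore estimated to give 100000 nM in this assay, with a likely range from 40000 nM to 250000 nM.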

Compound 4, half-maximal inhibitory concentration: 94900 nM
Beside the measured number, compound 4's estimate is 1.1-fold (0.02 log units) above it; low and high end bracket the measured number.
By their numbers in this assay, from the lowest: compounds 2, 4, 3 and 1 (each within the scatter of the next).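

Going by these compounds alone, exchanging diethylamino for cyclopropylamino on a thiocarbonyl carbon gives a 1.3-fold lower number from compound 1 to compound 4 (0.11 log units; within the scatter) in this assay and, for the first time, shows what a single change at this position does. The entering group brings one hydrogen-bond donor and a three-membered ring of carbon, neither of which the leaving group has, yet the step stays inside the usual spread of repeat measurements, so this swap separates compound 4 from compound 1 by nothing that can be told from noise. No measurement is available that would explain this result.

Going by these compounds, it remains open whether a longer chain such as octylamino, a benzylamino group or an amine carrying a carboxylic acid on the thiocarbonyl carbon would give a step beyond the scatter, or whether this position gives similar numbers whatever group it holds. It is also open whether a change elsewhere on the shared core, away from the thiocarbonyl carbon, would move the number more than this swap does, since every compound shown keeps that core unchanged.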